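Shortening the phosphate chain: from compound 2 to compound 4

The source may hold more compounds than are shown below. What is called first, only, known or untested is meant among the compounds shown, and "the series" means these compounds.

Measured compounds:
- compound 1 `Cc1cc(=O)n([C@@H]2O[C@H](COP(=O)(O)OP(=O)(O)OP(=O)(O)O)[C@@H](O)[C@H]2O)c(=O)[nH]1`; in an in vitro functional assay on 1321-N1 cells for agonist activity at P2Y purinoceptor 6 (Homo sapiens) (a lower number here means that less compound is needed, a higher number that more compound is needed for the effect), compound 1 gives the limit > 1000 nM.
- compound 2 `Cc1cc(=O)n([C@@H]2O[C@H](COP(=O)(O)OP(=O)(O)O)[C@@H](O)[C@H]2O)c(=O)[nH]1`; in this assay compound 2 gives the limit > 1000 nM.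
- compound 3 `CCCc1cc(=O)n([C@@H]2O[C@H](COP(=O)(O)OP(=O)(O)O)[C@@H](O)[C@H]2O)c(=O)[nH]1`; in this assay compound 3 gives the limit > 1000 nM.

Compound 2 stands at a limit of this assay only, and the two further values shown are limits as well: the limit of > 1000 nM in this assay, at which 3 of the 3 values shown sit. No number can be read for any of the three.

Going by the values given here, the only steps measured around compound 2 are therefore unreadable. The removal of a phosphate group from compound 1 to compound 2 gives a step that the two limits leave unreadable from compound 1 to compound 2, and the lengthening of the side chain from compound 2 to compound 3 gives a step that the two limits leave unreadable from compound 2 to compound 3. Neither shows whether agonist activity moved, nor by how much.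

Compound 4 `Cc1cc(=O)n([C@@H]2O[C@H](COP(=O)(O)O)[C@@H](O)[C@H]2O)c(=O)[nH]1` takes the phosphate chain one unit shorter again: a hydrogen atom in place of a group of 4 heavy atoms (3 oxygen, 1 phosphorus; no ring), on an oxygen. This repeats the kind of change made from compound 1 to compound 2, whose outcome is hidden by the limits.

With all three measured values sitting at the limit, the expectation for compound 4 in this assay is that the assay again reports only a limit, and the step from compound 2 to compound 4 is estimated as a step that the limit leaves unreadable from compound 2 to compound 4. The estimate for compound 4 is 5000 nM, within 1000 nM to 50000 nM.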

Compound 4, half-maximal effective concentration: > 100000 nM
Compound 4 was reported as a limit; the forecaster's own chance of this, stated with the estimate: 90%; at least 20-fold (1.30 log units) between middle value and limit.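

In this assay compound 4 gives > 100000 nM, which is a limit and not a number. Its steps from compound 1 and compound 2 therefore cannot be read. The compounds shown leave open whether shortening the phosphate chain changes agonist activity at all, since compound 1, compound 2, compound 3 and compound 4 all remain without a readable number.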